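The source may hold more compounds than are shown below. What is called first, only, known or untested is meant among the compounds shown, and "the series" means these compounds.

Compound 1 `ClCc1cccc(Cn2cnc3c(Cl)ncnc32)c1`: 79400 nM
Compound 2 `ClCc1ccc(Cn2cnc3nc(Cl)nc(Cl)c32)cc1`: 8310 nM
Compound 3 `ClCc1cccc(Cn2cnc3c(Cl)nc(Cl)nc32)c1`: 67600 nM

These three compounds were tested in a functional assay on OVCAR-8 cells (Homo sapiens) for cytotoxicity, read by sulforhodamine B assay, with a stated time of 48 h; on this read-out lower numbers stand for higher toxicity in this test and higher numbers for lower toxicity in this test. Compound 2 gives the lowest number of the three, with compound 3 and compound 1 both standing well beyond the scatter above it. Compound 3 and compound 1 share one core and differ in one place: hydrogen in place of chloro on an aromatic carbon. The step of a 1.2-fold higher number from compound 3 to compound 1 (0.07 log units; within the scatter).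

Compound 2 and compound 3 are built from the same atoms joined differently; how their cores differ is not broken down here. Compound 4 `ClCc1ccc(Cn2cnc3ncnc(Cl)c32)cc1` has not yet been tested in this assay. It differs from compound 2 in the same way that compound 1 differs from compound 3: hydrogen in place of chloro on an aromatic carbon.

Because the step of a 1.2-fold higher number from compound 3 to compound 1 (0.07 log units; within the scatter), the same change from compound 2 to compound 4 is expected to give a similar small step, a 1.1-fold higher number from compound 2 to compound 4 (0.06 log units; within the scatter), so compound 4 is estimated to give 9500 nM in this assay, with a likely range from 4500 nM to 20000 nM.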

Compound 4, concentration lethal to 50% of the cells: 56200 nM
The estimate for compound 4 lay 5.9-fold (0.77 log units) below the measured number, outside the stated range (above it).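

In this assay, putting hydrogen in place of chloro on the aromatic carbon between two ring nitrogen atoms gives a 6.8-fold higher number from compound 2 to compound 4 (0.83 log units; beyond the scatter). The same change therefore does not carry over from one core to the other with the same size, so a step seen on one core is a poor guide to the step on the other: the same change on two cores in this assay, a 1.2-fold higher number (0.07 log units; within the scatter) from compound 3 to compound 1 and a 6.8-fold higher number (0.83 log units; beyond the scatter) from compound 2 to compound 4, 5.8-fold (0.76 log units) apart, beyond the scatter of two such steps. Going by these compounds alone, this comparison rests on only two pairs of compounds; it shows that the core matters for the size of the step, but not which feature of the core is responsible or how the cells respond differently to the two pairs.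

Only chloro and hydrogen appear at this carbon among the compounds shown, so it remains open how an amine or a methoxy group there would read in this test. Within the data shown here, it also remains open whether this change on a third core would give a small step, like the one from compound 3 to compound 1, or a large one.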